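This account rests on a few compounds, and the source may have more. Where it says the series, first, only, none or still open, it means among the compounds named here.

Measured so far:
compound 1 `C=CC(=O)Nc1cccc(Nc2nc(N/N=C/c3ccc(F)cc3F)ncc2Cl)c1`: 4760 nM
compound 2 `C=CC(=O)Nc1cccc(Nc2nc(N/N=C(\C)c3ccncc3)ncc2Cl)c1`: 12800 nM

Going by the values given here, in an ADME assay on HT-29 cells (Homo sapiens) for inhibition, read by MTT assay, with a stated time of 72 h (on this read-out lower numbers stand for stronger inhibition and higher numbers for weaker inhibition), compound 1 gives 4760 nM, the lower of the two numbers; the only measured step, a 2.7-fold higher number from compound 1 to compound 2 (0.43 log units; beyond the scatter), concerns a different part of the shared core and does not touch the amide end. Compound 3 `CN(C)C/C=C/C(=O)Nc1cccc(Nc2nc(N/N=C/c3ccc(F)cc3F)ncc2Cl)c1` carries 3-(dimethylamino)prop-1-en-1-yl in place of vinyl on a carbonyl carbon. Among the compounds with values here, no measured pair reports a change at this carbonyl carbon, so the data give no direction for it; the step of a 1.1-fold lower number from compound 1 to compound 3 (0.02 log units; within the scatter) is expected to stay within the scatter. Compound 3 is estimated in this assay at 4500 nM, range 1500 nM to 13000 nM.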

Compound 3, half-maximal inhibitory concentration: 2920 nM
Estimate against measurement, compound 3: 1.5-fold (0.19 log units) above; the range from low to high includes it.
By their numbers in this assay, from the lowest: compounds 3 and 1 (each within the scatter of the next); then compound 2.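

Going by these compounds alone, at the carbonyl carbon, the first reading of this position comes from 3-(dimethylamino)prop-1-en-1-yl in place of vinyl: in this assay the step is a 1.6-fold lower number from compound 1 to compound 3 (0.21 log units; within the scatter), so the larger group leaves compounds 1 and 3 indistinguishable on this read-out. No available evidence bears on this result. Open, as far as these compounds go, is whether morpholine in place of the dimethylamino group, or a longer chain carrying the amine, would give a step beyond the scatter, and whether the same exchange on compound 2 would match this step.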